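Chloro to Fluoro: Metabolic Stability in Three Measured Compounds

The source may report more compounds than this note shows. Statements on the series, on what has been measured and on what is new or still open speak of the compounds shown alone.

Measured compounds:
- compound 1, `Fc1ccc(Cn2nnc3c(Br)cccc32)cc1`: 1 mL/min/g
- compound 2, `Clc1ccc(Cn2nnc3c(Br)cccc32)cc1`: 2 mL/min/g
- compound 3, `Clc1cc(Br)c2nnn(CC3CC3)c2c1`: 11.4 mL/min/g

All three were run in an ADME assay on microsomes from liver (Mus musculus, strain NMRI) for metabolic stability, tested at 2.5 uM; a lower number here means slower removal, a higher number faster removal of the compound. Compound 1 and compound 2 share a core and differ in a single place: fluoro in place of chloro on an aromatic carbon. The step this change made is a 2.0-fold lower number from compound 2 to compound 1 (0.30 log units; within the scatter), so the two numbers cannot be told apart with confidence.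

Compound 3 carries a different core, and the difference between the two cores is not broken down here. Compound 3 shows the highest number of the three, and its distance from both compound 2 and compound 1 lies beyond the scatter.

Compound 4, `Fc1cc(Br)c2nnn(CC3CC3)c2c1`, has not yet been measured. It differs from compound 3 by fluoro in place of chloro on an aromatic carbon. Going by the values given here, this is the same kind of change as the one between compound 2 and compound 1, but it sits in a different surrounding: in compound 4 the carbon is part of a fused system of two rings, meta to a bromo group, meta to a fused ring and para to a fused ring, whereas in compound 1 it is para to a large group.

In this assay the step from compound 3 to compound 4 is expected to be a 1.6-fold lower number from compound 3 to compound 4 (0.21 log units; within the scatter), resting on the earlier step of a 2.0-fold lower number from compound 2 to compound 1 (0.30 log units; within the scatter). Compound 4 is therefore estimated at 7 mL/min/g, with a range expected from 3 mL/min/g to 15 mL/min/g.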

Compound 4, intrinsic clearance in a liver preparation (reported as CLH), per the amount of preparation that the assay uses: 5.7 mL/min/g
For compound 4 the middle estimate is 1.2-fold (0.09 log units) above the measured one; measured number inside the range.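

In this assay, fluoro in place of chloro on an aromatic carbon gives a 2.0-fold lower number from compound 3 to compound 4 (0.30 log units; within the scatter). Set beside the same change on the core of compound 1, the two steps match: the same change on two cores in this assay, a 2.0-fold lower number (0.30 log units; within the scatter) from compound 2 to compound 1 and a 2.0-fold lower number (0.30 log units; within the scatter) from compound 3 to compound 4, 1.0-fold (0.00 log units) apart, within the scatter of two such steps

So on these two cores, the change comes with steps of matching size, and the step seen on one core would have served as a fair guide to the step on the other. It does not show that fluoro truly gives slower removal than chloro on either core, as each step taken alone stays within the scatter, and two cores are too few to support a rule for the whole series or to say why the steps match.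

The compounds shown leave open how a nitrile or a methoxy group in place of chloro would behave in this assay, since only chloro and fluoro appear at this carbon. They also leave open whether the steps would still match on a core without the bromo group, which all four compounds carry.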